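This account rests on a few compounds, and the source may have more. Where it says the series, first, only, none or still open, it means among the compounds named here.

Measured in a physicochemical assay, with a stated time of 6 min; a higher number here means a weaker inhibitor, a lower number a stronger inhibitor:
- compound 1 `O=C(Nc1ccc(I)cc1)Nc1nc(-c2cc3ccccc3o2)cs1`: 62000 nM
- compound 2 `O=C(Nc1ccc(F)cc1)Nc1nc(-c2cc3ccccc3o2)cs1`: 1130 nM
- compound 3 `COc1cccc(NC(=O)Nc2nc(-c3cc4ccccc4o3)cs2)c1`: 200 nM

Compound 3 has the lowest number of the three, which makes it the strongest inhibitor so far in this assay. The next compound, compound 4 `O=C(Nc1ccc([N+](=O)[O-])cc1)Nc1nc(-c2cc3ccccc3o2)cs1`, carries 4-nitrophenyl in place of 3-methoxyphenyl on an amide-type nitrogen. Going by the values given here, two measured steps bear most directly on this change. Replacing 4-fluorophenyl with 3-methoxyphenyl gave a modest step, a 5.7-fold lower number from compound 2 to compound 3 (0.75 log units; beyond the scatter), and replacing 4-iodophenyl with it gave a large one, a 310-fold lower number from compound 1 to compound 3 (2.49 log units; beyond the scatter). Compound 4 reverses that kind of swap, so a rise in the number is expected, probably modest but possibly large. Among the compounds with values here, the size is uncertain, since fluoro in place of iodo alone gave a 55-fold lower number from compound 1 to compound 2 (1.74 log units; beyond the scatter), and no nitro compound has been measured yet. The estimate means a 10-fold higher number from compound 3 to compound 4 (1.00 log units; beyond the scatter), an expected move towards weaker inhibition. For compound 4 the estimated value is 2000 nM, with an expected range of 400 nM to 15000 nM.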

Compound 4, half-maximal inhibitory concentration: 19300 nM
Compound 4: the middle estimate sits 9.7-fold (0.98 log units) below what was measured; the whole stated range lies below it.
By their numbers in this assay, from the lowest: compound 3; then compound 2; then compound 4; then compound 1.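

In this assay, 4-nitrophenyl on the amide-type nitrogen gives a 97-fold higher number from compound 3 to compound 4 (1.98 log units; beyond the scatter), which shows that a third group at this place falls far short of 3-methoxyphenyl. Nitro also differs clearly from both halogens: nitro in place of fluoro gives a 17-fold higher number from compound 2 to compound 4 (1.23 log units; beyond the scatter), whereas nitro in place of iodo gives a 3.2-fold lower number from compound 1 to compound 4 (0.51 log units; beyond the scatter). All three compounds with a 4-substituted phenyl group therefore have higher numbers than compound 3, and they spread widely among themselves, with compound 2 the lowest of them and compound 1 the highest.

Nothing available here accounts for these differences. Going by these compounds, what 4-methoxyphenyl or 4-aminophenyl would give on this nitrogen remains open, and with it whether the low number of compound 3 belongs to the methoxy group itself or to where it sits.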